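Aryl substituents: from 3-methylphenyl to 3-iodophenyl

The source may report more compounds than this note shows. Statements on the series, on what has been measured and on what is new or still open speak of the compounds shown alone.

Measured in a functional assay on SK-MEL-28 cells (Homo sapiens) for cytotoxicity, read by CCK-8 assay, with a stated time of 24 h; on this read-out lower numbers stand for stronger inhibition and higher numbers for weaker inhibition:
- compound 1 `COc1ccccc1Oc1c(N)nc(-c2ccccc2)nc1Cl`: 3140 nM
- compound 2 `COc1ccccc1Oc1c(N)nc(-c2cccc(C)c2)nc1Cl`: 54000 nM
- compound 3 `COc1ccccc1Oc1c(N)nc(-c2ccc(Br)cc2)nc1Cl`: 14 nM

Compound 2 has the highest number of the three and is the weakest in this assay. The next compound to be measured is compound 4 `COc1ccccc1Oc1c(N)nc(-c2cccc(I)c2)nc1Cl`, which differs from compound 2 by iodo in place of methyl on an aromatic carbon.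

Going by the values given here, three measured steps bear on this change. Methyl in place of hydrogen gave a 17-fold higher number from compound 1 to compound 2 (1.24 log units; beyond the scatter), so the methyl of compound 2 is tied to a large rise. Bromo in place of hydrogen gave a 220-fold lower number from compound 1 to compound 3 (2.35 log units; beyond the scatter), and the direct exchange of aryl groups gave a 3900-fold lower number from compound 2 to compound 3 (3.59 log units; beyond the scatter). Both steps are large, but compound 3 carries 4-bromophenyl rather than 3-iodophenyl, which makes it only a loose guide. Among the compounds with values here, no measured compound carries iodo, and none has a halogen meta to a large group. A drop from compound 2 is therefore expected, probably to near or somewhat below compound 1 at 3140 nM, with wide uncertainty.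

The expected step is a 36-fold lower number from compound 2 to compound 4 (1.56 log units; beyond the scatter).

Compound 4 is estimated at 1500 nM, with an expected range of 60 nM to 30000 nM.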

Compound 4, half-maximal inhibitory concentration: 4660 nM
For compound 4 the middle estimate is 3.1-fold (0.49 log units) below the measured one; the range from low to high includes it.
By their numbers in this assay, from the lowest: compound 3; then compounds 1 and 4 (each within the scatter of the next); then compound 2.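

In this assay, iodo in place of methyl gives a 12-fold lower number from compound 2 to compound 4 (1.06 log units; beyond the scatter), while iodo in place of hydrogen gives a 1.5-fold higher number from compound 1 to compound 4 (0.17 log units; within the scatter), so at this place on the ring, meta to a large group, methyl stands apart from hydrogen and iodo does not. A halogen on the aryl ring is thus not enough on its own to reach the low number of compound 3: the exchange of aryl groups gives a 330-fold higher number from compound 3 to compound 4 (2.52 log units; beyond the scatter), but the halogen and its place on the ring change together in that step, and their shares cannot be separated. No measurement among these compounds gives a reason for any of these differences.

Still open, going by these compounds, is whether the low number of compound 3 goes with bromo itself or with where it sits, a question that bromo at the place of the iodo of compound 4, or iodo at the place of the bromo of compound 3, would settle. Also open, on these data alone, is how the series responds at this place to groups of another kind, such as an amine or a carboxylic acid.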